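Swapping the aroyl group: compound 3 to compound 4

The compounds below may be only part of what the source reports. "The series", "measured", "known", "first", "only" and "open" are said of these compounds alone.

Three compounds share one core and were measured in a functional assay on HepG2 cells (Homo sapiens) for inhibition, read by MTT assay, with a stated time of 72 h; a higher number here means a weaker inhibitor, a lower number a stronger inhibitor. Compound 1 `CN(C(=O)NC(=O)c1ccc(Cl)cc1Cl)c1nc(C(F)(F)F)c(C(=O)N/N=C/c2cccc(C(F)(F)F)c2)s1` gives 11.2 ug/mL in this assay. Compound 2 `CN(C(=O)NC(=O)c1cccc(C(F)(F)F)c1)c1nc(C(F)(F)F)c(C(=O)N/N=C/c2ccccc2C(F)(F)F)s1` gives 10.4 ug/mL. Compound 3 `CN(C(=O)NC(=O)c1ccc(Cl)cc1Cl)c1nc(C(F)(F)F)c(C(=O)N/N=C/c2ccccc2C(F)(F)F)s1` gives 10.7 ug/mL, which places it second highest of the three numbers, though every gap to a neighbour lies within the scatter: the step of a 1.0-fold lower number from compound 1 to compound 3 (0.02 log units; within the scatter) and the step of a 1.0-fold higher number from compound 2 to compound 3 (0.01 log units; within the scatter) are both too small to read as real changes.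

Compound 4 `CN(C(=O)NC(=O)c1ccccc1F)c1nc(C(F)(F)F)c(C(=O)N/N=C/c2ccccc2C(F)(F)F)s1` has not yet been measured in this assay. It differs from compound 3 in one place: 2-fluorophenyl in place of 2,4-dichlorophenyl on a carbonyl carbon. For the measured compounds named here, the only measured step that touches the same position is the one from compound 2 to compound 3, where a 3-(trifluoromethyl)phenyl on the carbonyl carbon was replaced by 2,4-dichlorophenyl with no effect beyond the scatter. The exchange of the aryl group at the carbon bearing the double bond to nitrogen, from compound 1 to compound 3, likewise left the number unchanged.

On this basis compound 4 is expected to sit close to compound 3, with a step of a 1.0-fold higher number from compound 3 to compound 4 (0.01 log units; within the scatter) that stays within the scatter. The estimate for compound 4 in this assay is 11 ug/mL, with a range from 6 ug/mL to 22 ug/mL.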

Compound 4, half-maximal inhibitory concentration: 5.39 ug/mL
Estimate against measurement, compound 4: 2.0-fold (0.31 log units) above; measured number outside the range, below it.
By their numbers in this assay, from the lowest: compounds 4, 2, 3 and 1 (each within the scatter of the next, the first and the last beyond it).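

At the carbonyl carbon whose other neighbour is an amide-type nitrogen, the earlier exchange in this assay had produced a step of almost no size, a 1.0-fold higher number from compound 2 to compound 3 (0.01 log units; within the scatter), while 2-fluorophenyl gives steps of clearly greater size: a 2.0-fold lower number from compound 3 to compound 4 (0.30 log units; within the scatter) and a 1.9-fold lower number from compound 2 to compound 4 (0.29 log units; within the scatter). Both new steps remain within the scatter, so three different aryl groups, 2,4-dichlorophenyl, 3-(trifluoromethyl)phenyl and 2-fluorophenyl, have now stood at this place without a step that can be read as a real change, and the new result widens the span of steps seen here without establishing a preference among them. Nothing available here accounts for the size of these steps, and no measurement bears on their origin.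

The compounds shown leave open whether a group of another kind on this carbonyl carbon, such as an unsubstituted phenyl, a methoxyphenyl, a pyridyl ring or a cyclohexyl ring, would move the number beyond the scatter. They also leave open whether 2-fluorophenyl would give a similar step when 3-(trifluoromethyl)phenyl stands on the carbon with a double bond to nitrogen.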